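A few compounds are considered here, and "the series" means these few. Any claim that something is new, unique, unknown or untested is made for them only; others in the source may bear on it.

Compound 2 `COc1ccc(C2=C(c3cc(OC)c(OC)c(OC)c3)C(=O)C(O)C2)cc1` carries a free hydroxyl on a saturated carbon of the shared core. In an ADME assay on KB cells (Homo sapiens) for cytotoxicity, read by MTT assay, with a stated time of 72 h (on this read-out lower numbers stand for stronger inhibition and higher numbers for weaker inhibition), compound 2 gives < 1 ug/mL, which is a limit of the assay and not a number. Its place on the scale is the limit of < 1 ug/mL in this assay, at which 1 of the 3 values shown sits.

Two close relatives give actual numbers. Compound 1 `COc1ccc(C2=C(c3cc(OC)c(OC)c(OC)c3)C(=O)C(OC(C)=O)C2)cc1`, which has an acetyl on that same oxygen, gives 72 ug/mL. Compound 3 `COc1ccc(C2=C(c3cc(OC)c(OC)c(OC)c3)C(=O)C(O)C2)cc1Cl`, which also has a chloro on an aromatic carbon, gives 2.5 ug/mL.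

Compound 4 `COc1ccc(C2=C(c3cc(OC)c(OC)c(OC)c3)C(=O)C(O[SiH2]C(C)(C)C)C2)cc1` has not yet been measured, and its change from compound 2 is a group of 5 heavy atoms (4 carbon, 1 silicon; no ring) in place of a hydrogen atom, on an oxygen on a saturated carbon. The closest guide is the step at the same oxygen, an at least 72-fold lower number from compound 1 to compound 2 (1.85 log units; beyond the scatter), which read backwards shows that capping the hydroxyl goes with a much higher number. The other measured step, an at least 2.5-fold higher number from compound 2 to compound 3 (0.39 log units; beyond the scatter), lies on an aromatic carbon and bears on this change only weakly. Within the data shown here, no compound with the entering group has been measured, so the size of the change is uncertain.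

Because of an at least 72-fold lower number from compound 1 to compound 2 (1.85 log units; beyond the scatter) a clearly higher number is expected for compound 4 in this assay. The expected size is an at least 15-fold higher number from compound 2 to compound 4 (1.17 log units; beyond the scatter). The estimate for compound 4 is 15 ug/mL, with an expected range from 3 ug/mL to 70 ug/mL.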

Compound 4, half-maximal inhibitory concentration: 7 ug/mL
Compound 4: the middle estimate sits 2.1-fold (0.33 log units) above what was measured, within the range that was stated.
By their numbers in this assay, from the lowest: compound 3; then compound 4; then compound 1. At a limit, below all of these: compound 2.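

In this assay, a second kind of cap on the oxygen on a saturated carbon also goes with weaker inhibition than the free hydroxyl, with an at least 7.0-fold higher number from compound 2 to compound 4 (0.84 log units; beyond the scatter), so among the compounds shown this loss is not confined to the acetyl of compound 1. The identity of the cap matters as well: with a 10-fold lower number from compound 1 to compound 4 (1.01 log units; beyond the scatter), the group holding silicon retains clearly more of the inhibition than the acetyl does, so capping this oxygen does not by itself set the number. Compound 2 stands at a limit of the assay and not at a number, so the full size of the loss on capping remains unknown: the limit of < 1 ug/mL in this assay, at which 1 of the 4 values shown sits.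

The compounds shown leave open whether a much smaller cap, such as a methyl ether, would stay closer to compound 2, and whether replacing the hydroxyl with an amine would keep the inhibition. They also leave open how a cap on this oxygen would behave in combination with the chloro on an aromatic carbon found in compound 3.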